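A few compounds are considered here, and "the series" means these few. Any claim that something is new, unique, unknown or untested is made for them only; others in the source may bear on it.

Compound 1 `CC1CCN(C2CCN(S(=O)(=O)c3cccc(N)c3)CC2)CC1`: > 5000 nM
Compound 2 `CC1CCN(C2CCN(S(=O)(=O)c3cn(C)cn3)CC2)CC1`: > 10000 nM

In an ADME assay on HCT-116 cells (Homo sapiens) for cytotoxicity, read by CellTiter-Glo, with a stated time of 72 h (a higher number here means a weaker inhibitor, a lower number a stronger inhibitor), compound 2 gives > 10000 nM, which is a limit and not a number. Compound 1 gives > 5000 nM, which is also a limit. Compound 2 therefore has no exact place on the scale.

Compound 3 `CC1CCN(C2CCN(S(=O)(=O)c3cncc(Br)c3)CC2)CC1` keeps the shared core but carries 5-bromopyridin-3-yl in place of 1-methyl-1H-imidazol-4-yl on the sulfonyl sulfur: 5-bromopyridin-3-yl in place of 1-methyl-1H-imidazol-4-yl on a sulfonyl sulfur. Within the data shown here, one measured step bears on this change, a swap at the same place: a step that the two limits leave unreadable from compound 1 to compound 2. Its size cannot be read, so it offers no size to carry over, and no clear shift in either direction is expected.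

The expectation rests on compound 2, whose > 10000 nM is a limit. The expected step is a number no higher from compound 2 to compound 3 (the limit leaves the size open). The estimate for compound 3 is 10000 nM, with an expected range from 3000 nM to 30000 nM.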

Compound 3, half-maximal inhibitory concentration: > 10000 nM
Compound 3: only a limit was reported (the forecaster's own chance of this, stated with the estimate: 75%); the middle value sits exactly at the limit.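

Among these compounds, compound 1, compound 2 and compound 3 each give only a limit and not a number in this assay, and no step among them can be read. The compounds shown leave open how strongly each one acts in this assay, and whether the group on the sulfonyl sulfur changes this at all.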